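The source may report more compounds than this note shows. Statements on the series, on what has been measured and on what is new or still open speak of the compounds shown alone.

Measured in a physicochemical assay for solubility, with a stated time of 3 days, at pH 7; on this read-out higher numbers stand for higher solubility and lower numbers for lower solubility:
- Compound 1 `NC(=O)c1ccc2[nH]c(-c3ccc(OCCCO)cc3)nc2c1`: 7000 nM
- Compound 2 `CN1CCC(Oc2ccc(-c3nc4cc(C(N)=O)ccc4[nH]3)cc2)C1`: "not determined" (no result reported)

Only compound 1 gives a number in this assay, at 7000 nM. Compound 2 has no single number to stand on: its entry reads "not determined" (no result reported), so it cannot be placed relative to compound 1.

Compound 3 `NC(=O)c1ccc2[nH]c(-c3ccc(OC4CCCNC4)cc3)nc2c1` has not yet been measured. The structural change is piperidin-3-yl in place of 1-methylpyrrolidin-3-yl on an oxygen on an aromatic ring. Piperidin-3-yl takes the place of 1-methylpyrrolidin-3-yl on an oxygen on an aromatic ring, and the two structures have the same atoms, joined differently.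

Within the data shown here, no step between measured compounds is available, and with no result for compound 2, the change itself cannot be sized from the data. The expectation therefore rests on a single anchor, compound 1 at 7000 nM, and remains loose. A moderate upward step from that anchor, beyond the usual scatter of this assay, is expected, although a result close to it would not be surprising. For compound 3 the estimated value is 20000 nM, with an expected range of 4000 nM to 100000 nM.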

Compound 3, solubility: > 400000 nM
Compound 3: a limit, no number; the forecaster's own chance of this, stated with the estimate: 10%; middle value at least 20-fold (1.30 log units) away from the limit.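

In this assay compound 3 gives > 400000 nM, which is a limit of the assay and not a number. Among these compounds, on an oxygen on an aromatic ring, piperidin-3-yl in place of 3-hydroxypropyl gives an at least 57-fold higher number from compound 1 to compound 3 (1.75 log units; beyond the scatter), the first readable step at this position, and it shows that a change here alone can move the read-out by a large amount. The full size of that step stays unknown, and the change from 1-methylpyrrolidin-3-yl to piperidin-3-yl cannot be read at all, as compound 2 has no result, so the step rests on one pair and on a limit: the limit of > 400000 nM in this assay, at which 1 of the 3 values shown sits.

The compounds shown leave open whether the step belongs to the ring or to the amine, which a 3-aminopropyl chain or a tetrahydropyran-3-yl ring on the same oxygen would help to separate. They also leave open how the read-out responds to a 1-methylpiperidin-3-yl group there, and whether the amine in a piperidin-4-yl group would give a result that falls inside the range of the assay.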